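Replacing thiophen-2-yl with 1-benzofuran-2-yl on the shared core

The source may hold more compounds than are shown below. What is called first, only, known or untested is meant among the compounds shown, and "the series" means these compounds.

Measured so far in a functional assay on NCI-H460 cells (Homo sapiens) for cytotoxicity, read by MTT assay, with a stated time of 72 h (on this read-out lower numbers stand for stronger inhibition and higher numbers for weaker inhibition), are these compounds:
- compound 1 `CC(C)(C)c1[nH]cnc1/C=c1\[nH]c(=O)/c(=C/c2cccc(Oc3ccc(F)cc3)c2)[nH]c1=O` gives 4 nM as a number
- compound 2 `O=c1[nH]/c(=C\c2cccc(Oc3ccc(F)cc3)c2)c(=O)[nH]/c1=C\c1ccccc1` gives 389 nM as a number
- compound 3 `O=c1[nH]/c(=C\c2cccs2)c(=O)[nH]/c1=C\c1cccc(Oc2ccc(F)cc2)c1` gives > 1000 nM as a limit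

Compound 3 gives > 1000 nM as a limit of the assay and not as a number. Compound 4 `O=c1[nH]/c(=C\c2cc3ccccc3o2)c(=O)[nH]/c1=C\c1cccc(Oc2ccc(F)cc2)c1` differs from compound 3 in one place, and 1-benzofuran-2-yl in place of thiophen-2-yl on a double-bonded chain carbon bound to an aromatic carbon is the whole change. Among the measured compounds shown here, three measured steps touch that same place. Losing the 5-(tert-butyl)-1H-imidazol-4-yl group gave a 97-fold higher number from compound 1 to compound 2 (1.99 log units; beyond the scatter) with phenyl and an at least 250-fold higher number from compound 1 to compound 3 (2.39 log units; beyond the scatter) with thiophen-2-yl and both steps are large. Compound 2 and compound 3 already lack that group, as compound 4 does, and exchanging phenyl for thiophen-2-yl gave an at least 2.5-fold higher number from compound 2 to compound 3 (0.41 log units; beyond the scatter) so in this assay a modest step is expected rather than a large one, with slightly stronger inhibition the likelier direction. The estimated step is an at least 1.2-fold lower number from compound 3 to compound 4 (0.09 log units; that floor lies within the scatter) on this reasoning. Compound 4 is expected to give 800 nM with an estimated range from 250 nM to 3000 nM in this assay.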

Compound 4, half-maximal inhibitory concentration: 347 nM
The estimate for compound 4 lay 2.3-fold (0.36 log units) above the measured number; measured number inside the range.
By their numbers in this assay, from the lowest: compound 1; then compounds 4 and 2 (each within the scatter of the next). At a limit, above all of these: compound 3.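

In this assay, the step with 1-benzofuran-2-yl in place of thiophen-2-yl is an at least 2.8-fold lower number from compound 3 to compound 4 (0.45 log units; beyond the scatter), so at this position the group's identity matters even among groups that each hold a five-membered aromatic ring with one hetero atom. Compound 3 stands at a limit of the assay and not at a number, so this step gives only a floor: the limit of > 1000 nM in this assay, at which 1 of the 4 values shown sits. The larger group brings no clear gain over a plain ring, with a 1.1-fold lower number from compound 2 to compound 4 (0.05 log units; within the scatter), and it stays far from the 5-(tert-butyl)-1H-imidazol-4-yl group, with an 87-fold higher number from compound 1 to compound 4 (1.94 log units; beyond the scatter).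

The compounds shown leave open whether the imidazole ring or the tert-butyl group accounts for the strength of compound 1. A plain 1H-imidazol-4-yl group and a phenyl ring carrying tert-butyl would separate the two.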